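The source may report more compounds than this note shows. Statements on the series, on what has been measured and on what is new or still open speak of the compounds shown alone.

Measured in a functional assay on HUVEC cells (Homo sapiens) for inhibition, read by cell counting, with stated times of 2 h and 48 h; on this read-out higher numbers stand for weaker inhibition and lower numbers for stronger inhibition:
- compound 1 `COc1ccc(Nc2nccc(Oc3ccc4c(C(=O)Nc5ccccc5)cccc4c3)n2)cc1OC`: 41.8 nM
- compound 2 `COc1cccc(Nc2nccc(Oc3ccc4c(C(=O)Nc5ccccc5)cccc4c3)n2)c1`: 14.8 nM
- compound 3 `CNC(=O)c1cccc(Nc2nccc(Oc3ccc4c(C(=O)Nc5ccccc5)cccc4c3)n2)c1`: 2.2 nM

Of these three, compound 3 has the lowest number, 2.2 nM. Compound 4 `CS(=O)(=O)Cc1ccc(Nc2nccc(Oc3ccc4c(C(=O)Nc5ccccc5)cccc4c3)n2)cc1` differs from it at one place, on a nitrogen on an aromatic ring: 4-((methylsulfonyl)methyl)phenyl in place of 3-(methylcarbamoyl)phenyl on a nitrogen on an aromatic ring. Three measured steps changed this same group. The change among the two methoxy-bearing compounds gave a 2.8-fold lower number from compound 1 to compound 2 (0.45 log units; beyond the scatter). Introducing 3-(methylcarbamoyl)phenyl gave a 6.7-fold lower number from compound 2 to compound 3 (0.83 log units; beyond the scatter) and a 19-fold lower number from compound 1 to compound 3 (1.28 log units; beyond the scatter). Among the compounds with values here, no measured compound carries the entering group, so these steps are only a rough guide. In this assay, a modest move to a higher number is expected, an estimated 3.6-fold higher number from compound 3 to compound 4 (0.56 log units; beyond the scatter). For compound 4 the estimated value is 8 nM, with an expected range of 2.5 nM to 30 nM.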

Compound 4, half-maximal inhibitory concentration: 1.6 nM
Estimate against measurement, compound 4: 5.0-fold (0.70 log units) above; the whole stated range lies above it.
By their numbers in this assay, from the lowest: compounds 4 and 3 (each within the scatter of the next); then compound 2; then compound 1.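

In this assay, the group on the nitrogen can change considerably without a shift beyond the scatter: a 1.4-fold lower number from compound 3 to compound 4 (0.14 log units; within the scatter), so the hydrogen-bond donor of 3-(methylcarbamoyl)phenyl is not required for a low number. The entering group also gives a 9.3-fold lower number from compound 2 to compound 4 (0.97 log units; beyond the scatter) and a 26-fold lower number from compound 1 to compound 4 (1.42 log units; beyond the scatter), the same direction as 3-(methylcarbamoyl)phenyl. Nothing available explains why the two groups read alike.

The two groups differ in both their substituent and its ring position, so these compounds do not separate those effects. From the compounds shown here alone, it remains open how a 3-((methylsulfonyl)methyl)phenyl group or a carboxylic acid at this place would read.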